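From cyclohexylmethoxy to cyclopentylmethoxy on the shared core

The compounds below may be only part of what the source reports. "The series", "measured", "known", "first", "only" and "open" are said of these compounds alone.

Three ethers on the shared core have been read so far in a functional assay on ACHN cells (Homo sapiens) for antiproliferative activity, read by sulforhodamine B assay; on this read-out higher numbers stand for weaker inhibition of growth and lower numbers for stronger inhibition of growth. Compound 1 `CCCCCCOc1cccc(O)c1C(=O)/C=C/c1ccc(O)cc1` gives > 30000 nM, which is a limit and not a number. Compound 2 `O=C(/C=C/c1ccc(O)cc1)c1c(O)cccc1OCCC1CCCCC1` gives > 30000 nM, again a limit. Compound 3 `O=C(/C=C/c1ccc(O)cc1)c1c(O)cccc1OCC1CCCCC1` gives > 30000 nM, also a limit. The series therefore stands at the limit of > 30000 nM in this assay, at which 3 of the 3 values shown sit, and compound 3 has no numerical position within it.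

Compound 4 `O=C(/C=C/c1ccc(O)cc1)c1c(O)cccc1OCC1CCCC1` carries cyclopentyl in place of cyclohexyl on a saturated chain carbon bound to an oxygen on an aromatic ring, which also reads as cyclohexylmethoxy to cyclopentylmethoxy: cyclopentyl in place of cyclohexyl on a saturated chain carbon bound to an oxygen on an aromatic ring.

For the measured compounds named here, three measured steps bear on this change: a step that the two limits leave unreadable from compound 2 to compound 3, a step that the two limits leave unreadable from compound 1 to compound 3 and a step that the two limits leave unreadable from compound 1 to compound 2. Each alters the group on the same oxygen, none has a readable size, and none yields a number. They give no direction for the new change, so no step beyond the scatter is expected in this assay. The expected step is a number no higher from compound 3 to compound 4 (the limit leaves the size open), and the assay may well report only a limit again. Compound 4 is estimated at 30000 nM, with an expected range of 10000 nM to 60000 nM.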

Compound 4, concentration for 50% growth inhibition: 3510 nM
For compound 4 the middle estimate is 8.5-fold (0.93 log units) above the measured one; measured number below the stated range.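

For the compounds shown here, compound 4 is the first ether on the shared core to give a number rather than a limit in this assay, while the other ethers stay at that limit: the limit of > 30000 nM in this assay, at which 3 of the 4 values shown sit. Cyclopentyl in place of cyclohexyl on this saturated chain carbon gives an at least 8.5-fold lower number from compound 3 to compound 4 (0.93 log units; beyond the scatter), so this single change in the ring separates a number from a limit. Cyclopentyl in place of cyclohexylmethyl gives an at least 8.5-fold lower number from compound 2 to compound 4 (0.93 log units; beyond the scatter), and cyclopentyl in place of pentyl gives an at least 8.5-fold lower number from compound 1 to compound 4 (0.93 log units; beyond the scatter), so compound 4 also stands apart from the ether with the further chain carbon and from the open-chain ether, though each of these three steps has a limit at one end and its full size remains open.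

The steps among compound 1, compound 2 and compound 3 cannot be read, so those three ethers cannot be ordered against one another, and no reason for the result at compound 4 can be given from these values. As far as these compounds go, whether the number depends on the cyclopentyl ring itself remains open: a cyclobutylmethyl group, a cyclopentylethyl group or an amine on the chain would test this.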